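A few compounds are considered here, and "the series" means these few. Any claim that something is new, unique, unknown or untested is made for them only; others in the source may bear on it.

Measured compounds in the series:

compound 1 `O=C(O)CCc1cccc2c1B(O)OC2` — > 100000 nM
compound 2 `O=C(CCc1cccc2c1B(O)OC2)NC1CCCCC1` — > 100000 nM
compound 3 `CC(C)(C)c1ccc(NC(=O)CCc2cccc3c2B(O)OC3)cc1` — 33000 nM

In a functional assay on MDA-MB-231 cells (Homo sapiens) for antiproliferative activity, read by MTT assay, with a stated time of 72 h (a higher number here means a weaker inhibitor, a lower number a stronger inhibitor), compound 2 gives > 100000 nM, which is a limit of the assay and not a number. Compound 1 gives > 100000 nM in this assay, again a limit. Both sit at the limit of > 100000 nM in this assay, at which 2 of the 3 values shown sit, so the step that the two limits leave unreadable from compound 1 to compound 2 cannot be read. Among the measured compounds shown here, compound 3 is the only member with a number in this assay, where compound 3 gives 33000 nM.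

Compound 4 `O=C(CCc1cccc2c1B(O)OC2)Nc1cccc(Br)c1` is the next compound to be measured. Against compound 2 the change is 3-bromophenyl in place of cyclohexyl on an amide-type nitrogen. No measured step in this assay covers an aryl in place of cyclohexyl on the amide nitrogen; the only step shown, from compound 1 to compound 2, is unreadable. For the measured compounds named here, compound 3 carries an aryl amide on the same core and is the one member with a readable value, and the aryl amide of compound 4 is therefore placed near it, with a wide range because compound 2 supplies only a limit.

Compound 4 is expected in this assay at 40000 nM, within 12000 nM to 130000 nM. The expected step is an at least 2.5-fold lower number from compound 2 to compound 4 (0.39 log units; beyond the scatter), though its size rests on a limit and is uncertain.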

Compound 4, half-maximal inhibitory concentration: 720 nM
Compound 4: middle estimate off by 56-fold (1.74 log units), on the high side; the measured number lies below the stated range.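

Among the compounds shown here, the change to 3-bromophenyl in place of cyclohexyl on the amide-type nitrogen gives an at least 130-fold lower number from compound 2 to compound 4 (2.14 log units; beyond the scatter) in this assay, the first step that can be read, and it shows that this nitrogen substituent can carry a large change in antiproliferative activity. From the compounds shown here alone, compound 2 gives > 100000 nM, which is a limit of the assay and not a number, so the true size of the step stays open: the limit of > 100000 nM in this assay, at which 2 of the 4 values shown sit. Compound 3, also an aryl amide on the shared core, gives 33000 nM, and compound 4 gives 720 nM, so the presence of an aryl group on this nitrogen does not by itself set the value, and what the ring carries also counts.

The compounds shown do not separate the share of the aromatic ring from that of the bromine, a question that a plain phenyl amide or a chlorine in place of the bromine would address. They also leave open how the value responds to a longer chain between the shared core and the amide carbonyl.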